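The compounds below may be only part of what the source reports. "The series", "measured", "known", "first", "only" and "open" are said of these compounds alone.

Three analogues sharing one core were examined in a functional assay on HCT-116 cells (Homo sapiens) for inhibition, read by MTT assay, with a stated time of 72 h; on this read-out higher numbers stand for weaker inhibition and lower numbers for stronger inhibition. Compound 1 `COc1ccc2c(c1)/C(=N/NC(=S)N1CCN(c3ccccc3)CC1)C(=O)N2` gives 9530 nM. Compound 2 `O=C1Nc2cc(Br)ccc2/C1=N/NC(=S)N1CCN(c2ccccc2)CC1` gives 14500 nM. Compound 3 `COc1ccc(N2CCN(C(=S)N/N=C3\C(=O)Nc4ccc(Cl)cc43)CC2)cc1` gives 7740 nM. On the numbers shown compound 3 sits at the low end of the three, yet its gap to compound 1 and its gap to compound 2 both lie within the scatter, so no ordering of the three can be read from this assay.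

Compound 4 `O=C1Nc2ccc(Cl)cc2/C1=N/NC(=S)N1CCN(c2ccccc2Cl)CC1` is not yet measured. It differs from compound 3 in one place: 2-chlorophenyl in place of 4-methoxyphenyl on an amine nitrogen in a ring. Among the compounds with values here, no pair of measured compounds differing in exactly one place is available, so the size of this change has no precedent here. The three measured values of compound 1, compound 2 and compound 3 all lie close to one another despite differing substituents, and on that basis the expected step of a 1.2-fold higher number from compound 3 to compound 4 (0.07 log units; within the scatter) is not larger than the scatter, in no particular direction. Compound 4 is therefore estimated at 9000 nM, with a range from 4000 nM to 20000 nM.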

Compound 4, half-maximal inhibitory concentration: 4910 nM
Compound 4: middle estimate off by 1.8-fold (0.26 log units), on the high side; low and high end bracket the measured number.
By their numbers in this assay, from the lowest: compounds 4, 3, 1 and 2 (each within the scatter of the next, the first and the last beyond it).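

Across this assay, a 1.6-fold lower number from compound 3 to compound 4 (0.20 log units; within the scatter) gives the first reading of a single change at this site, on an amine nitrogen in the six-membered ring, and it lies within the scatter. The earlier compounds shown here could not show this, since none of them formed a pair differing in one place; here, exchanging 4-methoxyphenyl for 2-chlorophenyl, with the loss of one hydrogen-bond acceptor, produces no difference that can be told apart from repeat variation. No measurement is available that would explain this result.

Going by these compounds, whether a benzyl group, a pyridine ring or a small alkyl group such as methyl at this nitrogen would move the number beyond the scatter remains open. On these data alone, it is also open how an unsubstituted phenyl group would read on the core of compound 3.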